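Furan to thiophene in two dihydropyrimidine series

The source may hold more compounds than are shown below. What is called first, only, known or untested is meant among the compounds shown, and "the series" means these compounds.

Compound 1 `CC1=C(C(=O)OC(C)(C)C)C(c2ccoc2)NC(=S)N1` and compound 2 `CC1=C(C(=O)OC(C)(C)C)C(c2cccs2)NC(=S)N1` share one core and were measured in an assay on membranes from CHO cells for displacement of a labelled ligand from adenosine receptor A1 (Homo sapiens), read by scintillation counting, with a stated time of 60 min, tested at 1 uM; on this read-out lower numbers stand for less inhibition and higher numbers for more inhibition at the one concentration tested (going by the name of the read-out): compound 1 gives 18% and compound 2 gives 22%, a step of a number 4 percentage points higher from compound 1 to compound 2 (within the scatter) made by thiophen-2-yl in place of furan-3-yl on a saturated ring carbon. Compound 3 `CCC(CC)OC(=O)C1=C(C)NC(=O)NC1c1ccoc1` gives 17% in this assay; the difference between its core and the core of compound 1 is not broken down here. Compound 4 `CCC(CC)OC(=O)C1=C(C)NC(=O)NC1c1cccs1` has not been measured and differs from compound 3 by thiophen-2-yl in place of furan-3-yl on a saturated ring carbon. The surroundings are not identical: in compound 3 the place is next to the ring atom that bears a group of 8 heavy atoms, in compound 1 a group of 7 heavy atoms, so it is the same kind of change. From compound 3 to compound 4 the expected step is a number 4 percentage points higher from compound 3 to compound 4 (within the scatter), resting on the step of a number 4 percentage points higher from compound 1 to compound 2 (within the scatter). Compound 4 is therefore expected to give 21%, between 9% and 33%.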

Compound 4, a percentage reported as inhibition, at one concentration (the size of the read-out at that concentration, not a potency): 13%
Compound 4: middle estimate off by 8 percentage points, on the high side, within the range that was stated.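

In this assay, thiophen-2-yl in place of furan-3-yl on the second core gives a number 4 percentage points lower from compound 3 to compound 4 (within the scatter). Set beside the earlier step, the two readings compare as follows: the same change on two cores in this assay, a number 4 percentage points higher (within the scatter) from compound 1 to compound 2 and a number 4 percentage points lower (within the scatter) from compound 3 to compound 4, 8 percentage points apart, within the scatter of two such steps. This gives no sign that the change behaves differently on the two cores, but since each step lies within the scatter, it does not show that the change has any effect on either core, or that an effect carries from one to the other.

The compounds shown hold only these two five-membered aromatic rings at this place, so they leave open what a phenyl ring or an amine-bearing chain there would give. From the compounds shown here alone, whether any such group would move the number beyond the scatter also remains open.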